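Carbonyl-side replacement in the pyridyl-pyrazole series

The source may hold more compounds than are shown below. What is called first, only, known or untested is meant among the compounds shown, and "the series" means these compounds.

Of the compounds shown here, three have been measured in a functional assay on ACHN cells (Homo sapiens) for inhibition, read by sulforhodamine B assay, with a stated time of 48 h, tested at 100 uM; a lower number here means a stronger effect, a higher number a weaker effect of the compound at the concentration tested. Compound 1 `O=C(Nc1cccc(-n2cc(-c3ccncc3)c(-c3cc(O)cc(Cl)c3)n2)c1)Nc1ccc(Cl)c(Cl)c1` gives -33% in this assay. Compound 2 `COc1cc(Cl)cc(-c2nn(-c3cccc(NC(=O)Nc4cc(C(F)(F)F)cc(C(F)(F)F)c4)c3)cc2-c2ccncc2)c1` gives -38%. Compound 3 `COc1cc(Cl)cc(-c2nn(-c3cccc(NC(=O)Nc4ccc(Cl)c(Cl)c4)c3)cc2-c2ccncc2)c1` gives 6%, the highest of the three numbers: the step of a number 39 percentage points higher from compound 1 to compound 3 (beyond the scatter), methyl in place of hydrogen on an oxygen on an aromatic ring, lies beyond the scatter, and the gap to compound 2 is of similar size. For the measured compounds named here, compound 2 and compound 3 differ on the aryl attached to the amide-type nitrogen; no step is given for that pair, only the two values stand.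

Compound 4 `COc1cc(Cl)cc(-c2nn(-c3cccc(NC(=O)c4cccc(C(F)(F)F)c4)c3)cc2-c2ccncc2)c1` is not yet measured. It differs from compound 3 by 3-(trifluoromethyl)phenyl in place of (3,4-dichlorophenyl)amino on a carbonyl carbon. Going by the values given here, no measured step touches the carbonyl carbon or the group on it, so nothing here speaks directly to the size or direction of this change. Among the compounds with values here, the one measured step, from compound 1 to compound 3, concerns a distant position and gives no guide. Within the data shown here, with the hydrogen-bond donor of the leaving group gone and no comparable pair in hand, the expected step of a number 6 percentage points lower from compound 3 to compound 4 (within the scatter) is set near zero with a wide range. Compound 4 is estimated at 0% in this assay, between -40% and 35%.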

Compound 4, a percentage reported as activity, at one concentration (the size of the read-out at that concentration, not a potency): 40%
Estimate against measurement, compound 4: 40 percentage points below; measured number above the stated range.
By their numbers in this assay, from the lowest: compounds 2 and 1 (each within the scatter of the next); then compound 3; then compound 4.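

For the compounds shown here, the carbonyl carbon is the first position on this side of the series to be read directly: in this assay, putting 3-(trifluoromethyl)phenyl in place of (3,4-dichlorophenyl)amino gives a step of a number 34 percentage points higher from compound 3 to compound 4 (beyond the scatter), so the group on this carbon is not a silent part of the structure. The step runs towards a weaker effect at the concentration tested, the same direction as the change on the distant oxygen, a number 39 percentage points higher from compound 1 to compound 3 (beyond the scatter), although the two steps sit at different places and one does not explain the other. No measurement of any property bears on why the number moves at this position.

As far as these compounds go, the step removes the amide hydrogen and changes the aryl substituents at once, so the share of each stays open; (3,4-dichlorophenyl)carbonyl or (3-(trifluoromethyl)phenyl)amino on the same carbon would separate the two. Also open, from the compounds shown here alone, are whether the step holds with the free hydroxyl of compound 1 on the far ring, and what a non-aromatic group on the carbonyl carbon, such as a piperidine amine or a short alkyl chain, would give.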